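A few compounds are considered here, and "the series" means these few. Any claim that something is new, unique, unknown or untested is made for them only; others in the source may bear on it.

In an ADME assay on HEK-293T cells (Homo sapiens) for inhibition, read by CCK-8 assay, with a stated time of 48 h, tested at 20 uM (on this read-out lower numbers stand for less inhibition of growth and higher numbers for more inhibition of growth at the one concentration tested), compound 1 (`COc1ccc(S(=O)(=O)Oc2ccccc2/C=C(\C#N)C(=O)Nc2nnc(Cc3ccccc3)s2)cc1`) gives 23%, compound 2 (`N#C/C(=C\c1ccccc1OS(=O)(=O)c1ccccc1[N+](=O)[O-])C(=O)Nc1nnc(Cc2ccccc2)s1`) gives 10% and compound 3 (`N#C/C(=C\c1ccccc1OS(=O)(=O)c1ccc(F)cc1)C(=O)Nc1nnc(Cc2ccccc2)s1`) gives 6%. Compound 2 therefore lies well under compound 1 and cannot be told apart from compound 3. The measured steps are a number 13 percentage points lower from compound 1 to compound 2 (beyond the scatter), a number 17 percentage points lower from compound 1 to compound 3 (beyond the scatter) and a number 4 percentage points lower from compound 2 to compound 3 (within the scatter). All of them alter the group on the sulfonyl sulfur. Compound 4 (`N#C/C(=C\c1ccccc1OS(=O)(=O)c1ccccc1[N+](=O)[O-])C(=O)Nc1nnc(Cc2ccc(Cl)cc2)s1`) keeps that group from compound 2 and instead has chloro in place of hydrogen on an aromatic carbon, turning benzyl to 4-chlorobenzyl. Among the compounds with values here, no measured step tests this change, so the evidence is indirect, and no shift beyond the scatter is expected. The expected step is a number 1 percentage points higher from compound 2 to compound 4 (within the scatter). Compound 4 is estimated at 11%, with a range of 3% to 28%.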

Compound 4, percent growth inhibition at one concentration: 20%
The estimate for compound 4 lay 9 percentage points below the measured number, and the stated range covers the measured number.
By their numbers in this assay, from the lowest: compounds 3, 2, 4 and 1 (each within the scatter of the next, the first and the last beyond it).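

Unlike the other steps, which alter the group on the sulfonyl sulfur, this one changes benzyl to 4-chlorobenzyl, and in this assay it gives a number 10 percentage points higher from compound 2 to compound 4 (within the scatter) and so leaves compound 2 and compound 4 indistinguishable. With the 2-nitrophenyl group in place, this pair therefore shows no clear effect of chloro at this position. Nothing available explains the result. Going by these compounds, whether an amine or a carboxylic acid at this position would give a clearer step remains open, as does whether chloro would behave the same with the 4-methoxyphenyl group of compound 1.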